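Adding a Carboxymethyl Group to Compound 2

This account rests on a few compounds, and the source may have more. Where it says the series, first, only, none or still open, it means among the compounds named here.

Compound 1 `CC[C@H](C)[C@H](NC(=O)CN(c1nc(Cl)nc2[nH]cnc12)C1CC1)C(=O)O` and compound 2 `O=C(O)CNC(=O)CN(c1nc(Cl)nc2[nH]cnc12)C1CC1` share one core. In a functional assay on the whole organism (Tail, strain ICR) with Mus musculus as the target, in the tail flick test, with a stated time of 30 min, at a dose of 25 umol/kg by the oral route (on this read-out lower numbers stand for a weaker effect and higher numbers for a stronger effect at the one dose given), compound 1 gives 30.3%, and compound 2 gives 32.2%. Compound 2 holds the higher of these two numbers, with compound 1 within the scatter, and the change a number 1.9 percentage points higher from compound 1 to compound 2 (within the scatter) shows how little that chain carbon mattered so far. Compound 3 `O=C(O)C[C@H](NC(=O)CN(c1nc(Cl)nc2[nH]cnc12)C1CC1)C(=O)O` differs from compound 2 by carboxymethyl in place of hydrogen on a saturated chain carbon bound to an amide-type nitrogen and a carbonyl carbon. Among the compounds with values here, with only that small earlier step as a guide, the expected step of a number 1.2 percentage points lower from compound 2 to compound 3 (within the scatter) is none beyond the scatter. Compound 3 is therefore estimated at 31%, between 14% and 48%.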

Compound 3, a percentage reported as activity, at one dose (the size of the read-out at that dose, not a potency): 19.9%
Compound 3: middle estimate off by 11.1 percentage points, on the high side, within the range that was stated.
By their numbers in this assay, from the lowest: compound 3; then compounds 1 and 2 (each within the scatter of the next).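

This chain carbon is not indifferent to what it carries: in this assay carboxymethyl in place of hydrogen gives a number 12.3 percentage points lower from compound 2 to compound 3 (beyond the scatter) and carboxymethyl in place of sec-butyl gives a number 10.4 percentage points lower from compound 1 to compound 3 (beyond the scatter) as a second modest step beyond the scatter. Hydrogen and sec-butyl had not separated beyond the scatter, so among these three compounds only carboxymethyl stands apart. Nothing measured here explains this drop. Still open, on these data alone, is whether a plain methyl, an amine or a longer chain ending in a carboxylic acid on this carbon would give a similar drop.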